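This account rests on a few compounds, and the source may have more. Where it says the series, first, only, none or still open, it means among the compounds named here.

Compound 2 `CC(C)(O)c1cn(Cc2nnc(-c3cc(S(N)(=O)=O)c(SCc4ccccc4)cc3Cl)o2)nn1` stands at the lower of the two numbers in hand: in a functional assay on HCT-116 cells (Homo sapiens) for cytotoxicity, read by MTT assay, with a stated time of 72 h (a higher number here means a weaker inhibitor, a lower number a stronger inhibitor), compound 2 gives 82000 nM, while compound 1 `CCOC(=O)c1cn(Cc2nnc(-c3cc(S(N)(=O)=O)c(SCc4ccccc4)cc3Cl)o2)nn1` gives 108000 nM in this assay, and the step of a 1.3-fold lower number from compound 1 to compound 2 (0.12 log units; within the scatter) lies within the scatter. Compound 3 `NS(=O)(=O)c1cc(-c2nnc(CNC(=O)c3ccccc3)o2)c(Cl)cc1SCc1ccccc1` is the next member of the series, differing from compound 2 by benzamido in place of 4-(1-hydroxy-1-methylethyl)-1H-1,2,3-triazol-1-yl on a saturated chain carbon bound to an aromatic carbon. Within the data shown here, the one measured step concerns a change elsewhere, at the group on the triazole, and so does not bear on this exchange; no measured pair shows what happens when the triazole itself is replaced. With nothing in hand pointing either way, compound 3 is expected to sit near compound 2, with a step of a 1.0-fold lower number from compound 2 to compound 3 (0.01 log units; within the scatter) in this assay that need not exceed the scatter. The estimate for compound 3 is therefore 80000 nM, within a range from 30000 nM to 200000 nM.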

Compound 3, half-maximal inhibitory concentration: 42000 nM
Estimate against measurement, compound 3: 1.9-fold (0.28 log units) above; the range from low to high includes it.
By their numbers in this assay, from the lowest: compounds 3, 2 and 1 (each within the scatter of the next, the first and the last beyond it).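

At the saturated chain carbon bound to an aromatic carbon, the triazole itself can be exchanged in this assay: benzamido in place of 4-(1-hydroxy-1-methylethyl)-1H-1,2,3-triazol-1-yl gives a 2.0-fold lower number from compound 2 to compound 3 (0.29 log units; within the scatter), so this exchange does not separate the two compounds. Benzamido in place of 4-(ethoxycarbonyl)-1H-1,2,3-triazol-1-yl gives a 2.6-fold lower number from compound 1 to compound 3 (0.41 log units; beyond the scatter), a modest step and the first in this series to lie beyond the scatter. Nothing in hand gives a reason for either step.

The compounds shown leave open whether the step depends on the amide carbonyl or on the benzene ring, which acetamido or a free amine on the same carbon would help to separate. They also leave open how substituents on the benzene ring of benzamido, such as chloro or methoxy, would read in this assay.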